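Swapping an Amide for a Methylimidazole: Expected Mouse Exposure

This account rests on a few compounds, and the source may have more. Where it says the series, first, only, none or still open, it means among the compounds named here.

Of the compounds shown here, three with a shared core have been measured in an ADME assay on the whole organism (plasma, strain 129/SvEvBrd x C57BL/6) for pharmacokinetics, with Mus musculus as the target, at a dose of 10 mg/kg by the oral route; on this read-out lower numbers stand for lower exposure and higher numbers for higher exposure at the dose given. Compound 1 `CC(=O)c1cccc([C@@H](O)[C@H](O)[C@H](O)CO)n1` gives 10500 ng.h/mL. Compound 2 `CN(C)C(=O)c1nc([C@@H](O)[C@H](O)[C@H](O)CO)c[nH]1` gives 1740 ng.h/mL, the second highest of the three numbers, nearer to compound 3 `OC[C@@H](O)[C@@H](O)[C@H](O)c1c[nH]c(-c2ncn(Cc3ccccc3)n2)n1`, which gives 587 ng.h/mL, than to compound 1; both gaps lie beyond the usual scatter. Compound 4 `Cn1cnc(-c2nc([C@@H](O)[C@H](O)[C@H](O)CO)c[nH]2)c1` has not been measured. It differs from compound 2 in one place: 1-methyl-1H-imidazol-4-yl in place of dimethylcarbamoyl on an aromatic carbon. Going by the values given here, no step between measured compounds matches this change, so the expectation rests on compound 3, whose value 587 ng.h/mL sits below compound 2 and which likewise carries a second aromatic ring in place of the amide. Compound 4 is therefore expected to show a modest drop, a 1.9-fold lower number from compound 2 to compound 4 (0.29 log units; within the scatter), likely beyond the scatter, with an estimated 900 ng.h/mL and a range from 350 ng.h/mL to 2200 ng.h/mL.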

Compound 4, area under the concentration-time curve: 698 ng.h/mL
Compound 4: middle estimate off by 1.3-fold (0.11 log units), on the high side; the measured number falls inside the stated range.
By their numbers in this assay, from the lowest: compounds 3 and 4 (each within the scatter of the next); then compound 2; then compound 1.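

In this assay, going by these compounds alone, putting 1-methyl-1H-imidazol-4-yl in place of dimethylcarbamoyl on this aromatic carbon gives a 2.5-fold lower number from compound 2 to compound 4 (0.40 log units; beyond the scatter), the first direct reading of a change at this position. The step shows that an aromatic ring can replace the amide here with a modest loss of exposure, not a collapse. No measurement at hand explains the drop.

The compounds shown leave open how a carboxylic acid or a primary amide would behave at this position. They also leave open whether an imidazole without its methyl would keep the same exposure.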